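The compounds below may be only part of what the source reports. "The series", "measured", "known", "first", "only" and "open" are said of these compounds alone.

Measured compounds:
compound 1 `COC(=O)c1ccc(OCCCCOc2ccc(C(=O)CC3CCCC3)c(O)c2C)cc1` — in an assay on HEK293 cells for positive allosteric modulation of metabotropic glutamate receptor 2 (Rattus norvegicus), read by thallium flux, with a stated time of 2.5 min (on this read-out lower numbers stand for an effect already at smaller amounts and higher numbers for an effect only at larger amounts of compound), compound 1 gives "not determined" (no result reported)
compound 2 `Cc1ccc(C(=O)O)cc1OCCCCOc1ccc(C(=O)CC(C)C)c(O)c1C` — in this assay compound 2 gives 454 nM

Among the measured compounds shown here, compound 2 stands as the only number in hand in this assay; compound 1 carries no result, so no step between measured compounds can be read. Compound 3 `Cc1ccc(C(=O)O)cc1OCCCCOc1ccc(C(=O)CC2CCCC2)c(O)c1C` differs from compound 2 by cyclopentyl in place of isopropyl on a saturated chain carbon bound to a carbonyl carbon. With nothing measured across this change, the expected step is small and not beyond the scatter, in either direction. Compound 3 is expected at 320 nM, within 110 nM to 950 nM, an estimated step of a 1.4-fold lower number from compound 2 to compound 3 (0.15 log units; within the scatter).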

Compound 3, half-maximal effective concentration: 1290 nM
Compound 3: the middle estimate sits 4.0-fold (0.61 log units) below what was measured, and the stated range ends below it.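

In this assay, the saturated chain carbon bound to a carbonyl carbon does respond to the group it carries: cyclopentyl in place of isopropyl gives a 2.8-fold higher number from compound 2 to compound 3 (0.45 log units; beyond the scatter). This single pair shows that the larger carbon-only ring goes with a higher number here, not with a gain. Nothing measured on these compounds accounts for the step.

Going by these compounds, whether the step follows the ring or the added carbons stays open. A cyclopropyl group or a straight butyl chain at this place would bear on that question.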